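The compounds below may be only part of what the source reports. "The series", "measured", "known", "first", "only" and "open" are said of these compounds alone.

Compound 1, `CCOC(=O)Cc1nc(N)n(C(=O)c2ccccc2)n1`, gives 31.6% in a functional assay on the whole organism (strain albino) for inhibition, with Rattus norvegicus as the target, read by paw edema, with stated times of 30 min and 1 h, at a dose of 5 mg/kg by the oral route; a higher number here means more inhibition at the dose given (going by the name of the read-out), a lower number less inhibition.
Compound 2, `CCOC(=O)Cc1nc(N)n(C(=O)c2ccc(Br)cc2)n1`, gives 34.8% in this assay.

Within the data shown here, compound 2 holds the higher of the two numbers, but the only measured step, a number 3.2 percentage points higher from compound 1 to compound 2 (within the scatter), is within the scatter, so the two compounds cannot be told apart on these data. Compound 3 is `CCOC(=O)Cc1nc(N)n(C(=O)c2ccc(OC)cc2)n1`. It differs from compound 2 in one place: methoxy in place of bromo on an aromatic carbon. Among the measured compounds shown here, the single measured step, a number 3.2 percentage points higher from compound 1 to compound 2 (within the scatter), concerns bromo in place of hydrogen on an aromatic carbon and was within the scatter; no measured step exchanges bromo for methoxy. With nothing to point one way or the other, no step beyond the scatter is expected, and the step from compound 2 to compound 3 is estimated at a number 2.8 percentage points lower from compound 2 to compound 3 (within the scatter). Compound 3 is therefore expected to give about 32%, within a range from 18% to 46%.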

Compound 3, a percentage reported as inhibition, in the whole organism at one dose (the size of the read-out at that dose, not a potency): 32.8%
Compound 3: middle estimate off by 0.8 percentage points, on the low side; the measured number falls inside the stated range.
By their numbers in this assay, from the lowest: compounds 1, 3 and 2 (each within the scatter of the next).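

Methoxy now joins bromo at this place on the aromatic ring, para to a large group, and in this assay the new group also stays within the scatter against both neighbours: there is a number 2 percentage points lower from compound 2 to compound 3 (within the scatter) and a number 1.2 percentage points higher from compound 1 to compound 3 (within the scatter). Hydrogen, bromo and methoxy therefore cannot be told apart here, even though methoxy has a hydrogen-bond acceptor and bromo has none, so adding that acceptor at this place brings no readable change in this read-out. Nothing available explains this flat result. Still open, going by these compounds, is whether a group of another kind at this place, such as an amine or a carboxylic acid, would give a number beyond the scatter. Also open, on these data alone, is whether a change elsewhere on the shared core would matter more than this one.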